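Removing the pyrimidine from a sulfonamide

A few compounds are considered here, and "the series" means these few. Any claim that something is new, unique, unknown or untested is made for them only; others in the source may bear on it.

Compound 1 `Cc1cc(C)nc(NS(=O)(=O)c2ccc(Nc3nncc4ccccc34)cc2)n1` gives 0.08 nM
Compound 2 `S=C(NNc1nncc2ccccc12)Nc1ccccc1` gives 0.6 nM

Only these two compounds have been measured in a functional assay on SK-OV-3 cells (Homo sapiens) for antiproliferative activity, read by sulforhodamine B assay, with a stated time of 72 h (a higher number here means a weaker inhibitor, a lower number a stronger inhibitor), so far. Compound 1 has the lower number (0.08 nM), and the gap to compound 2 (0.6 nM) lies beyond the usual scatter. Compound 3 `NS(=O)(=O)c1ccc(Nc2nncc3ccccc23)cc1` is compound 1 with hydrogen in place of 4,6-dimethylpyrimidin-2-yl on a sulfonamide nitrogen and is still unmeasured. Going by the values given here, no measured pair shows this change, so any forecast is uncertain. Compound 1 (0.08 nM) carries the 4,6-dimethylpyrimidin-2-yl, whereas compound 2 (0.6 nM) lacks it, so a moderate move towards a higher number, beyond the scatter, is expected in this assay. The estimated change is a 5.0-fold higher number from compound 1 to compound 3 (0.70 log units; beyond the scatter) (a weaker result). For compound 3 the expected value is 0.4 nM (estimated range 0.08 nM to 2.5 nM).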

Compound 3, half-maximal inhibitory concentration: 0.8 nM
Beside the measured number, compound 3's estimate is 2.0-fold (0.30 log units) below it, and the stated range covers the measured number.
By their numbers in this assay, from the lowest: compound 1; then compounds 2 and 3 (each within the scatter of the next).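

In this assay, replacing the 4,6-dimethylpyrimidin-2-yl on the sulfonamide nitrogen with hydrogen gives a 10-fold higher number from compound 1 to compound 3 (1.00 log units; beyond the scatter) and thus a direct one-place comparison, which the earlier pair could not offer. The step lies beyond the scatter, so the group matters at this position, yet compound 3 at 0.8 nM shows that strong activity on these cells does not depend on it. No measurement at hand explains this shift.

Still open, going by these compounds, is whether the difference belongs to this particular group or to any substituent on that nitrogen: a methyl group, an acetyl group, a phenyl ring or a pyrimidine without its two methyl groups would help separate these possibilities. Compound 2 differs from compound 1 and compound 3 in more than one place, so it cannot settle the question.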